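The compounds below may be only part of what the source reports. "The series", "measured", "known", "first", "only" and "open" are said of these compounds alone.

Compound 1 is `Cc1nc(NCC2CCC2)nc(N[C@@H]2C[C@H](CO)[C@@H](O)[C@H]2O)c1-c1nc2ccccc2s1`. In an ADME assay on cells (Homo sapiens) for cytotoxicity, read by polymerase chain reaction, with a stated time of 3 days (on this read-out higher numbers stand for lower toxicity in this test and lower numbers for higher toxicity in this test), compound 1 reaches only the assay limit, > 25000 nM.
Compound 2 is `CCOCCNc1nc(C)c(-c2nc3ccccc3s2)c(N[C@@H]2C[C@H](CO)[C@@H](O)[C@H]2O)n1`; in this assay compound 2 gives 18000 nM.
Compound 3 is `Cc1nc(NCc2nccs2)nc(N[C@@H]2C[C@H](CO)[C@@H](O)[C@H]2O)c1-c1nc2ccccc2s1`; in this assay compound 3 gives 23000 nM.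

Compound 3 holds the higher of the two numbered values, with a 1.3-fold higher number from compound 2 to compound 3 (0.11 log units; within the scatter), and the value of compound 1 is a limit, (the limit of > 25000 nM in this assay, at which 1 of the 3 values shown sits). Compound 4 is `Cc1nc(NCc2ccccn2)nc(N[C@@H]2C[C@H](CO)[C@@H](O)[C@H]2O)c1-c1nc2ccccc2s1`; its difference from compound 3 is pyridin-2-yl in place of 1,3-thiazol-2-yl on a saturated chain carbon bound to a nitrogen on an aromatic ring. The measured steps at this same place, an at least 1.3-fold lower number from compound 1 to compound 2 (0.14 log units; that floor lies within the scatter), an at least 1.0-fold lower number from compound 1 to compound 3 (0.03 log units; that floor lies within the scatter) and a 1.3-fold higher number from compound 2 to compound 3 (0.11 log units; within the scatter), all stay within the scatter. A step of similar size, a 1.0-fold lower number from compound 3 to compound 4 (0.02 log units; within the scatter), is therefore expected, none beyond the scatter. Compound 4 is estimated at 22000 nM in this assay, within 12000 nM to 40000 nM.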

Compound 4, half-maximal cytotoxic concentration: 13000 nM
The estimate for compound 4 lay 1.7-fold (0.23 log units) above the measured number; the range from low to high includes it.
By their numbers in this assay, from the lowest: compounds 4, 2 and 3 (each within the scatter of the next). At a limit, above all of these: compound 1.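

Pyridin-2-yl shows that a six-membered aromatic ring on this saturated chain carbon leaves the result in this assay within the scatter of the five-membered 1,3-thiazol-2-yl and of ethoxymethyl, with a 1.8-fold lower number from compound 3 to compound 4 (0.25 log units; within the scatter) and a 1.4-fold lower number from compound 2 to compound 4 (0.14 log units; within the scatter). Against cyclobutyl only a floor can be read, an at least 1.9-fold lower number from compound 1 to compound 4 (0.28 log units; that floor lies within the scatter), and the true size of that step stays unknown: the limit of > 25000 nM in this assay, at which 1 of the 4 values shown sits.

The compounds shown leave open whether an amine or a carboxylic acid on this chain carbon would move the number beyond the scatter.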